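Mirror image of the weakest stereoisomer in the mouse

This account rests on a few compounds, and the source may have more. Where it says the series, first, only, none or still open, it means among the compounds named here.

Three stereoisomers of one molecule have been tested in a functional assay on the whole organism for inhibition, with Mus musculus as the target; on this read-out lower numbers stand for an effect already at smaller amounts and higher numbers for an effect only at larger amounts of compound. Compound 1, `CCCSc1nsnc1[C@H]1CN2CCC[C@@H]1C2`, gives 0.021 mg/kg. Compound 2, `CCCSc1nsnc1[C@@H]1CN2CCC[C@H]1C2`, gives 0.17 mg/kg. Compound 3, `CCCSc1nsnc1[C@H]1CN2CCC[C@H]1C2`, gives 2.21 mg/kg, the highest number of the three, so it needs the largest dose. The steps between them are all stereochemical: an 8.1-fold higher number from compound 1 to compound 2 (0.91 log units; beyond the scatter), a 110-fold higher number from compound 1 to compound 3 (2.02 log units; beyond the scatter) and a 13-fold higher number from compound 2 to compound 3 (1.11 log units; beyond the scatter). Inverting a single stereocentre at a saturated ring carbon thus costs far more than inverting the whole arrangement, as the mirror-image pair of compound 1 and compound 2 shows.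

Compound 4, `CCCSc1nsnc1[C@@H]1CN2CCC[C@@H]1C2`, is the mirror image of compound 3: the two compounds have the same atoms and bonds; at least one stereo element is drawn with a configuration in one of them and without one in the other: 2 of 3 stereo elements differ; a stereocentre at a saturated ring carbon is drawn R in compound 3 and S in compound 4; a stereocentre at a saturated ring carbon is drawn R in compound 3 and S in compound 4. Because the step of an 8.1-fold higher number from compound 1 to compound 2 (0.91 log units; beyond the scatter) shows that a full mirror inversion shifts the number by a modest amount, compound 4 is expected to stay in the weak region of compound 3 rather than return to the potency of compound 1. The expected step is a 2.2-fold lower number from compound 3 to compound 4 (0.34 log units; beyond the scatter), with the direction uncertain, since the mirror pair of compound 1 and compound 2 shows the gap can fall either way. For compound 4 the estimated value in this assay is 1 mg/kg, within a range from 0.15 mg/kg to 7 mg/kg.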

Compound 4, dose for half-maximal effect: 2.2 mg/kg
The estimate for compound 4 lay 2.2-fold (0.34 log units) below the measured number; the measured number falls inside the stated range.
By their numbers in this assay, from the lowest: compound 1; then compound 2; then compounds 4 and 3 (each within the scatter of the next).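

In this assay, the second mirror-image pair behaves differently from the first: the step is a 1.0-fold lower number from compound 3 to compound 4 (0.00 log units; within the scatter), whereas compound 1 and compound 2, also mirror images, lie apart by a step beyond the scatter. Inverting both stereocentres therefore has no fixed effect on the dose needed, since it matters in one pair and not in the other. Changing only one stereocentre gives a large step to compound 4 from either member of the first pair, as with a 13-fold higher number from compound 2 to compound 4 (1.11 log units; beyond the scatter) and a 100-fold higher number from compound 1 to compound 4 (2.02 log units; beyond the scatter), so compound 3 and compound 4 together form a group that needs much larger doses than compound 1 and compound 2.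

The compounds shown do not tell why the mirror-image gap appears only in the pair of compound 1 and compound 2, as a whole-animal dose alone cannot separate the possible reasons. They also leave open whether the same order of stereoisomers would hold if a longer chain or an amine replaced the propyl chain on the sulfur.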